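The source may hold more compounds than are shown below. What is called first, only, known or untested is meant among the compounds shown, and "the series" means these compounds.

Measured in a functional assay on HCT-116 cells (Homo sapiens) for inhibition, read by CCK-8 assay, with a stated time of 72 h, tested at 8 uM; on this read-out higher numbers stand for more inhibition of growth at the one concentration tested and lower numbers for less inhibition of growth:
- compound 1 `Nc1ccccc1NC(=O)/C=C/c1ccc(CSc2ccc(Cl)cc2)cc1`: 3.27%
- compound 2 `COc1ccc(SCc2ccc(C(=O)Nc3ccccc3N)cc2)cc1`: 90.1%
- compound 3 `COc1ccc(SCc2ccc(C(=O)Nc3ccccc3N)cc2)cc1OC`: 91.5%

Compound 2, at 90.1%, sits level with compound 3, at 91.5%, within the usual scatter, and both lie far above compound 1, at 3.27%.

Compound 4 `Cc1cc(C)cc(SCc2ccc(C(=O)Nc3ccccc3N)cc2)c1` has not yet been measured. It keeps the rest of compound 2 and changes only the group on the sulfur, with 3,5-dimethylphenyl in place of 4-methoxyphenyl on a sulfur.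

Among the compounds with values here, only one measured step changes this group: a number 1.4 percentage points higher from compound 2 to compound 3 (within the scatter), from methoxy in place of hydrogen on an aromatic carbon. It is a small step, and it is a single example of a different change. Compound 1 differs from compound 2 in more than one place and offers no single-change comparison. No step beyond the scatter is therefore expected in this assay, though a modest fall cannot be excluded.

The estimated change is a number 4.1 percentage points lower from compound 2 to compound 4 (within the scatter).

For compound 4 the estimate is 86%, with an expected range from 65% to 97%.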

Compound 4, percent growth inhibition at one concentration: 72.9%
For compound 4 the middle estimate is 13.1 percentage points above the measured one, within the range that was stated.
By their numbers in this assay, from the lowest: compound 1; then compound 4; then compounds 2 and 3 (each within the scatter of the next).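

In this assay, within the data shown here, the group on the sulfur is not a free choice: a number 17.2 percentage points lower from compound 2 to compound 4 (beyond the scatter), whereas the one earlier change at this group, a number 1.4 percentage points higher from compound 2 to compound 3 (within the scatter), left the number level. Both groups are six-membered aromatic rings of carbon only, but 4-methoxyphenyl carries a hydrogen-bond acceptor and 3,5-dimethylphenyl carries none. This single step cannot separate losing the methoxy group from gaining the methyl groups, and nothing measured here explains the fall.

As far as these compounds go, it remains open whether the methoxy group itself matters or whether the methyl groups are what lowers the number. Rings bearing a hydroxy group, an amine or a carboxylic acid on the sulfur would show how far the result depends on the kind of group the ring carries.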